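The compounds below may be only part of what the source reports. "The series", "measured", "known", "first", "only" and "open" are said of these compounds alone.

In an ADME assay on AG1523 cells (Homo sapiens) for cytotoxicity, read by MTT assay, with a stated time of 72 h (a lower number here means a stronger inhibitor, a higher number a weaker inhibitor), compound 2, whose structure is `CN1CCN(c2ccc(NC(=N)c3cc4c(-c5ccccc5)nn(C)c4cn3)cc2)CC1`, gives 10400 nM. Going by the values given here, this is the only number available in this assay: compound 1, with the structure `COc1ccc(Cn2nc(-c3ccccc3)c3cc(C(=N)Nc4ccccc4)ncc32)cc1`, carries no value here, its outcome being recorded as "not determined" (no result reported), so compound 2 stands alone and cannot be ranked against anything else.

Compound 3, with the structure `COc1ccc(Cn2nc(-c3ccccc3)c3cc(C(=N)Nc4ccc(N5CCN(C)CC5)cc4)ncc32)cc1`, shares the core of compound 2 and differs from it in one place: 4-methoxyphenyl in place of hydrogen on a saturated chain carbon bound to an aromatic nitrogen, which is to say 4-methoxyphenyl in place of hydrogen on a saturated chain carbon bound to an aromatic nitrogen. Among the compounds with values here, no pair of measured compounds shows this change. Within the data shown here, the size of the step in this assay is therefore not known from the data, and any expectation rests on the single value of compound 2 alone.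

The change is expected to lower the half-maximal inhibitory concentration modestly, by a step of a 1.7-fold lower number from compound 2 to compound 3 (0.24 log units; within the scatter), a shift that may well stay within the scatter of repeated measurements. Compound 3 is therefore estimated at 6000 nM, with a plausible range from 2000 nM to 20000 nM.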

Compound 3, half-maximal inhibitory concentration: 10200 nM
The estimate for compound 3 lay 1.7-fold (0.23 log units) below the measured number; low and high end bracket the measured number.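

In this assay the swap at this position amounts to a 1.0-fold lower number from compound 2 to compound 3 (0.01 log units; within the scatter) and so leaves compound 2 and compound 3 indistinguishable in this read-out. Going by these compounds alone, this pair gives the first direct look at the position on a saturated chain carbon bound to an aromatic nitrogen, which was out of reach while only one number existed. Here, methyl and 4-methoxybenzyl give numbers within the usual scatter of each other, even though the change adds 4-methoxyphenyl, with its 8 heavy atoms and six-membered aromatic ring. Nothing available explains why the two numbers match.

A single pair cannot show whether this holds for every group at this position, and a carboxylic acid, an amine or a longer chain there might give quite a different number. It also leaves open whether methyl and 4-methoxybenzyl would again match if the rest of the shared core carried different groups.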